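The source may hold more compounds than are shown below. What is called first, only, known or untested is meant among the compounds shown, and "the series" means these compounds.

In a functional assay on OVCAR-3 cells (Homo sapiens) for antiproliferative activity, read by spectrophotometry, with a stated time of 2 days (a higher number here means a weaker inhibitor of growth, a lower number a stronger inhibitor of growth), compound 1 `Cc1ccc(Nc2ncc(C(F)(F)F)c(N3Cc4cccc(N(C)S(C)(=O)=O)c4C3)n2)c(Cl)c1` gives > 30000 nM, which is a limit of the assay. Compound 2 `CN(c1cccc2c1CN(c1nc(Nc3cc(C(F)(F)F)cc(C(F)(F)F)c3)ncc1C(F)(F)F)C2)S(C)(=O)=O` gives > 30000 nM, again a limit, and so stands at the limit of > 30000 nM in this assay, at which 2 of the 2 values shown sit. Compound 3 `COc1cc(Nc2ncc(C(F)(F)F)c(N3Cc4cccc(N(C)S(C)(=O)=O)c4C3)n2)cc(C(F)(F)F)c1` keeps the shared core of compound 2 but carries methoxy in place of trifluoromethyl on an aromatic carbon, meta to a large group and meta to a trifluoromethyl group. Within the data shown here, no measured step shows what such a change does in this assay, so no change beyond the scatter is expected, and the estimated step is a number no higher from compound 2 to compound 3 (the limit leaves the size open). Compound 3 is expected to give 30000 nM, with an estimated range from 10000 nM to 60000 nM.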

Compound 3, concentration for 50% growth inhibition: > 30000 nM
Compound 3: only a limit was reported; the forecaster's own chance of this, stated with the estimate: 70%; the middle value lies on the limit itself.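

No step from compound 1 or compound 2 to compound 3 can be read in this assay, because all three stand at a limit: the limit of > 30000 nM in this assay, at which 3 of the 3 values shown sit.

The compounds shown leave open what methoxy in place of trifluoromethyl on an aromatic carbon does to growth inhibition in this assay.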